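The compounds below may be only part of what the source reports. "The series", "measured", "known", "first", "only" and "open" are said of these compounds alone.

Compound 1 `C[C@@H](O[C@H]1CN2C(=O)C=C(c3ccc(CO)cc3)CC2[C@@H]1c1ccc(F)cc1)c1cc(C(F)(F)F)cc(C(F)(F)F)c1` is the starting point. Going by the values given here, in an assay on CHO cells for displacement of a labelled ligand from Substance-P receptor (Homo sapiens) (on this read-out lower numbers stand for stronger inhibition and higher numbers for weaker inhibition), compound 1 gives 0.39 nM, the lowest of the two numbers measured so far. Compound 2 `C[C@@H](O[C@H]1CN2C(=O)C=C(c3cnn(Cc4ccccc4)c3)CC2[C@@H]1c1ccc(F)cc1)c1cc(C(F)(F)F)cc(C(F)(F)F)c1` gives 1.9 nM in this assay; the change a 4.9-fold higher number from compound 1 to compound 2 (0.69 log units; beyond the scatter) shows how a different group on that double-bonded ring carbon shifts the read-out. Compound 3 `C[C@@H](O[C@H]1CN2C(=O)C=C(C3=CCC(O)CC3)CC2[C@@H]1c1ccc(F)cc1)c1cc(C(F)(F)F)cc(C(F)(F)F)c1` has not been measured; it differs from compound 1 by 4-hydroxycyclohex-1-en-1-yl in place of 4-(hydroxymethyl)phenyl on a double-bonded ring carbon. Among the compounds with values here, only the step to compound 2 bears on this, and it was modest. For compound 3 a similar, modest weakening is therefore expected, a 3.8-fold higher number from compound 1 to compound 3 (0.59 log units; beyond the scatter). Compound 3 is estimated at 1.5 nM, likely between 0.4 nM and 6 nM.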

Compound 3, half-maximal inhibitory concentration: 0.18 nM
The estimate for compound 3 lay 8.3-fold (0.92 log units) above the measured number, outside the stated range (below it).
By their numbers in this assay, from the lowest: compound 3; then compound 1; then compound 2.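

Replacing the aromatic ring of compound 1 with a non-aromatic ring carrying one double bond does not cost binding at this double-bonded ring carbon: in this assay there is a 2.2-fold lower number from compound 1 to compound 3 (0.34 log units; beyond the scatter) and thus stronger inhibition. The same group also gives an 11-fold lower number from compound 2 to compound 3 (1.02 log units; beyond the scatter) so the earlier weakening was no general penalty for replacing 4-(hydroxymethyl)phenyl. No measurement here explains either shift. The compounds shown leave open whether the hydroxyl of 4-hydroxycyclohex-1-en-1-yl is needed, and whether an amine or a carboxylic acid in its place would keep the number this low.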